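Amide nitrogen substituent in a thiazolylpropyl guanidine urea series

The compounds below may be only part of what the source reports. "The series", "measured", "known", "first", "only" and "open" are said of these compounds alone.

Measured compounds:
compound 1 `Cc1nc(N)sc1CCCN/C(N)=N/C(=O)NC1CCCCC1` — 170 nM
compound 2 `CCCCCNC(=O)/N=C(\N)NCCCc1sc(N)nc1C` — 4.47 nM

In an assay on membranes from Sf9 cells for displacement of a labelled ligand from histamine H2 receptor (Homo sapiens), read by scintillation counting, with a stated time of 60 min (a higher number here means a weaker inhibitor, a lower number a stronger inhibitor), compound 2 gives 4.47 nM, the lowest of the two numbers recorded so far; its nearest neighbour is compound 1, which in this assay gives 170 nM. Within the data shown here, the single step available, a 38-fold lower number from compound 1 to compound 2 (1.58 log units; beyond the scatter), is large and well beyond the scatter.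

Compound 3 `Cc1nc(N)sc1CCCN/C(N)=N/C(=O)NC(C)c1ccco1` has not yet been measured. It differs from compound 2 by 1-(furan-2-yl)ethyl in place of pentyl on an amide-type nitrogen. Among the measured compounds shown here, the only measured step that touches this nitrogen is a 38-fold lower number from compound 1 to compound 2 (1.58 log units; beyond the scatter), in which a group carrying a ring gave way to a chain with no ring and the number fell sharply. The new group in compound 3 again carries a ring, which pentyl does not, so a move back toward a higher number seems the more likely direction, though the entering group is not the one that was measured and the size of the effect is uncertain.

Compound 3 is therefore expected to give a higher number in this assay, estimated at 40 nM with a range from 8 nM to 200 nM. The step this estimate implies is an 8.9-fold higher number from compound 2 to compound 3 (0.95 log units; beyond the scatter), expected to be smaller than the one seen between the two measured compounds.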

Compound 3, inhibition constant: 31.6 nM
Compound 3: middle estimate off by 1.3-fold (0.10 log units), on the high side, and the stated range covers the measured number.
By their numbers in this assay, from the lowest: compound 2; then compound 3; then compound 1.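

In this assay, the third group on this amide-type nitrogen gives a graded order rather than a single contrast: 1-(furan-2-yl)ethyl in place of pentyl gives a 7.1-fold higher number from compound 2 to compound 3 (0.85 log units; beyond the scatter) and, in place of cyclohexyl, gives a 5.4-fold lower number from compound 1 to compound 3 (0.73 log units; beyond the scatter) and so sits between the two earlier groups. Among these three compounds, the pentyl chain, the only group with no ring, gives the lowest number, and no compound shown goes against that order. The presence of a ring does not by itself fix the number, since the two ring-bearing groups stand apart beyond the scatter, and nothing available accounts for any of these differences.

Because 1-(furan-2-yl)ethyl differs from cyclohexyl and pentyl in more than one feature, the compounds shown do not separate the contribution of the furan ring from that of the methyl-bearing carbon linking it to the nitrogen. Open questions are how a furan-2-ylmethyl group, lacking that methyl, would compare with 1-(furan-2-yl)ethyl, and whether a longer chain such as heptyl would extend or reverse the low number seen with pentyl.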